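Cyclohexylamino on the shared core: expected shift in cytotoxicity

A few compounds are considered here, and "the series" means these few. Any claim that something is new, unique, unknown or untested is made for them only; others in the source may bear on it.

Among the measured compounds shown here, compound 2 `COc1ccc(Cn2nc(-c3ccccc3)c3cc(C(=N)Nc4ccccc4)ncc32)cc1` is the only member of the series with a number; in a functional assay on HT-1080 cells (Homo sapiens) for cytotoxicity, read by MTT assay, with a stated time of 72 h (on this read-out lower numbers stand for stronger inhibition and higher numbers for weaker inhibition), compound 2 gives 4700 nM. Compound 1 `COc1ccc(Cn2nc(-c3ccccc3)c3cc(C(=N)Nc4cccc(C(F)(F)F)c4)nc(NC4CCCCC4)c32)cc1` carries both a cyclohexylamino group and a trifluoromethyl group, but in this assay compound 1 gives "not determined" (no result reported), so no comparison is available from it. Compound 3 `COc1ccc(Cn2nc(-c3ccccc3)c3cc(C(=N)Nc4ccccc4)nc(NC4CCCCC4)c32)cc1` is the next case. Compared with compound 2 it differs in one place: cyclohexylamino in place of hydrogen on an aromatic carbon, the entering group being cyclohexylamino with its ring of carbon only. For the measured compounds named here, no step between two measured compounds covers this change, so the size and direction have to be inferred without precedent. A moderate gain beyond the usual scatter is expected, though a result within the scatter of compound 2 cannot be ruled out. The step from compound 2 to compound 3 is estimated at a 2.1-fold lower number from compound 2 to compound 3 (0.33 log units; beyond the scatter). In this assay compound 3 is expected to give 2200 nM, with a range from 500 nM to 9000 nM.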

Compound 3, half-maximal inhibitory concentration: 3400 nM
Compound 3: the middle estimate sits 1.5-fold (0.19 log units) below what was measured; the range from low to high includes it.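

Cyclohexylamino in place of hydrogen on an aromatic carbon, next to the ring nitrogen, gives a 1.4-fold lower number from compound 2 to compound 3 (0.14 log units; within the scatter) in this assay, the first step in the series with a number at both ends. This carbon therefore carries cyclohexylamino, with its ring of carbon only, without a read-out that can be separated from that of compound 2 with its hydrogen, so neither a gain nor a loss can be claimed for the change. Nothing on hand bears on why the two compounds read alike.

As far as these compounds go, one entering group says little about this carbon in general, and it remains open whether a methylamino group, a morpholine or a carboxylic acid at the same place would also leave the value within the scatter of compound 2. The trifluoromethyl group also stays unread, and with it any step from compound 3: in this assay compound 1 gives "not determined" (no result reported).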